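Flavone series: aryl variation at the ring-oxygen carbon

This account rests on a few compounds, and the source may have more. Where it says the series, first, only, none or still open, it means among the compounds named here.

Three members of the shared core have been run through a functional assay on A549 cells (Homo sapiens) for cytotoxicity, read by MTT assay, with a stated time of 72 h (on this read-out lower numbers stand for stronger inhibition and higher numbers for weaker inhibition), so far. Compound 1 `COc1c(OCCCCN2CCN(C)CC2)cc(O)c2c(=O)cc(-c3ccc(Cl)cc3)oc12` gives 1430 nM in this assay. Compound 2 `COc1c(OCCCCN2CCN(C)CC2)cc(O)c2c(=O)cc(-c3ccc(C(F)(F)F)cc3)oc12` gives 2890 nM. Compound 3 `COc1ccccc1-c1cc(=O)c2c(O)cc(OCCCCN3CCN(C)CC3)c(OC)c2o1` gives 6790 nM, the highest of the three numbers; the gap is a 4.7-fold higher number from compound 1 to compound 3 (0.68 log units; beyond the scatter) and a 2.3-fold higher number from compound 2 to compound 3 (0.37 log units; beyond the scatter), and between the two halogenated members a 2.0-fold higher number from compound 1 to compound 2 (0.31 log units; beyond the scatter).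

Compound 4 `COc1c(OCCCCN2CCN(C)CC2)cc(O)c2c(=O)cc(-c3ccc(F)cc3Br)oc12` is not yet measured. Relative to compound 3 the change is 2-bromo-4-fluorophenyl in place of 2-methoxyphenyl on an aromatic carbon. Both measured steps that bear on it run in the same direction: exchanging a 4-chlorophenyl or a 4-(trifluoromethyl)phenyl for 2-methoxyphenyl raised the number each time, modestly but beyond the scatter. Returning to a halogen-bearing phenyl is therefore expected to lower the number in this assay, most plausibly back toward the range of compounds 1 and 2; the bromine has no precedent here, so the size is uncertain. For compound 4 an estimate of 2500 nM (range 1000 nM to 6500 nM) is made, corresponding to an expected step of a 2.7-fold lower number from compound 3 to compound 4 (0.43 log units; beyond the scatter).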

Compound 4, half-maximal inhibitory concentration: 2980 nM
The estimate for compound 4 lay 1.2-fold (0.08 log units) below the measured number; the range from low to high includes it.
By their numbers in this assay, from the lowest: compound 1; then compounds 2 and 4 (each within the scatter of the next); then compound 3.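

In this assay, a substituent numbered 2 on the phenyl no longer goes with the highest number: 2-bromo-4-fluorophenyl and 2-methoxyphenyl share that numbering, yet they separate (with a 2.3-fold lower number from compound 3 to compound 4 (0.36 log units; beyond the scatter)). The new group cannot be told apart from 4-(trifluoromethyl)phenyl (with a 1.0-fold higher number from compound 2 to compound 4 (0.01 log units; within the scatter)), while 4-chlorophenyl keeps the lowest number of the series (with a 2.1-fold higher number from compound 1 to compound 4 (0.32 log units; beyond the scatter)), so this position accepts quite different halogen-bearing phenyl groups within a narrow band, and only compound 3 stands clearly higher. Nothing available gives a reason for these differences.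

The compounds shown do not separate the share of the bromo group from that of the fluoro group in the step from compound 3 to compound 4. Going by these compounds, how a phenyl carrying an amine or a carboxylic acid would read at this position also remains open.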